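The source may report more compounds than this note shows. Statements on the series, on what has been measured and on what is new or still open speak of the compounds shown alone.

Measured so far, in a functional assay on CHO cells with adenosine receptor A1 (Homo sapiens) as the target, read by cAMP accumulation and immunoassay, with a stated time of 6 min, tested at 10 uM; a higher number here means a weaker effect of the compound at the concentration tested, a lower number a stronger effect:

compound 1 `Nc1scc(CN2CCN(c3cc(F)cc(F)c3)CC2)c1C(=O)c1ccc(Cl)cc1`, value -79%
compound 2 `Nc1scc(CN2CCN(c3c(F)cccc3F)CC2)c1C(=O)c1ccc(Cl)cc1`, value -80%
compound 3 `Nc1scc(CN2CCN(c3cccc(F)c3F)CC2)c1C(=O)c1ccc(Cl)cc1`, value -79%

Compound 3 stands level with compound 1 at the digits printed, the two together the highest of the three numbers; its nearest neighbour is compound 1, with no change at the digits printed from compound 1 to compound 3 (within the scatter), its furthest compound 2, with a number 1 percentage points higher from compound 2 to compound 3 (within the scatter). Neither gap exceeds the scatter, nor does a number 1 percentage points lower from compound 1 to compound 2 (within the scatter), so the three difluorophenyl isomers read as one level in this assay.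

Compound 4 `Nc1scc(CN2CCN(CCCc3ccc(Cl)cc3)CC2)c1C(=O)c1ccc(Cl)cc1` differs from compound 3 as follows: 3-(4-chlorophenyl)propyl in place of 2,3-difluorophenyl on an amine nitrogen in a ring.

All three measured steps swap one difluorophenyl for another on the same ring nitrogen and all lie within the scatter. None replaces the aryl group with an arylalkyl chain of the kind entering here, so they give no measure of this change. The expectation for compound 4 is therefore anchored on the shared level of compounds 1 to 3 but carries a wide margin, and the step of a number 9 percentage points higher from compound 3 to compound 4 (within the scatter) is estimated as a modest move toward a higher number. For compound 4 the expected value in this assay is -70%, with a range from -98% to -30%.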

Compound 4, a percentage reported as activity, at one concentration (the size of the read-out at that concentration, not a potency): -76%
For compound 4 the middle estimate is 6 percentage points above the measured one; the range from low to high includes it.
By their numbers in this assay, from the lowest: compounds 2, 1, 3 and 4 (each within the scatter of the next).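

In this assay the 3-(4-chlorophenyl)propyl group on the ring nitrogen stays at the level of all three difluorophenyl compounds, with a number 3 percentage points higher from compound 3 to compound 4 (within the scatter) and a number 4 percentage points higher from compound 2 to compound 4 (within the scatter) and a number 3 percentage points higher from compound 1 to compound 4 (within the scatter) as the steps that show it. The earlier steps shown here only moved fluorine around one aryl ring, whereas these show that the read-out at this position also stays level when the ring is held on a propyl chain and carries chlorine in place of fluorine. No supporting data bear on why this level is kept.

On these data alone, whether the level holds without any aromatic ring on this nitrogen, as with a plain alkyl chain, an amine or a carboxylic acid, remains open, as does the effect of a longer chain. The read-out comes from a single concentration, so it shows only the size of the effect of these four compounds at that concentration.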